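Changing the Charged Group at the Chain End

This account rests on a few compounds, and the source may have more. Where it says the series, first, only, none or still open, it means among the compounds named here.

Compound 2 `CN(C)c1ccc2c(=O)c(C(=O)Nc3cc(F)cc(F)c3)cn(-c3ccc(Cl)c(OCCCCCCC[N+]45CCN(CC4)CC5)c3)c2n1` gives 8.08% in an assay on LX2 cells for inhibition of COL1A1 promoter (Homo sapiens), read by a luciferase reporter, with a stated time of 24 h, tested at 20 uM (a lower number here means a weaker effect, a higher number a stronger effect of the compound at the concentration tested), the highest of the two numbers available; compound 1 `Cc1ccc(-n2cc(C(=O)Nc3cc(F)cc(F)c3)c(=O)c3ccc(N(C)C)nc32)cc1OCCCCCCC[N+]12CCN(CC1)CC2` stands nearest with 5.07%, and compound 3 `CN(C)c1ccc2c(=O)c(C(=O)Nc3cc(F)cc(F)c3)cn(-c3ccc(OCCCCCCC[N+]4(C)CCCC4)cc3F)c2n1` is reported as "not active" (no number reported). Within the data shown here, the only measured step, a number 3 percentage points higher from compound 1 to compound 2 (within the scatter), concerns a change on an aromatic carbon and stays within the scatter. Compound 4 `CN(C)c1ccc2c(=O)c(C(=O)Nc3cc(F)cc(F)c3)cn(-c3ccc(Cl)c(OCCCCCCC[n+]4ccccc4)c3)c2n1` differs from compound 2 by a group of 6 heavy atoms (5 carbon, 1 nitrogen; one six-membered aromatic ring with 1 hetero atom) in place of a group of 8 heavy atoms (6 carbon, 2 nitrogen; 2 six-membered non-aromatic rings with 2 hetero atoms each), on a saturated chain carbon, seven bonds along the chain from an oxygen on an aromatic ring. Among the measured compounds shown here, no measured step touches this part of the chain, and compound 3, which differs from compound 2 in more than one place, gives no number. With nothing in the data pointing to a change, the expected step of a number 1.1 percentage points lower from compound 2 to compound 4 (within the scatter) is not beyond the scatter. Compound 4 is therefore estimated at 7%, ranging from 0% to 20%.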

Compound 4, a percentage reported as inhibition, at one concentration (the size of the read-out at that concentration, not a potency): "not active" (no number reported)
The entry for compound 4 holds no number, and the estimate cannot be compared.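

Among these compounds, no step from compound 2 to compound 4 can be read, as compound 4 is reported in this assay as not active, without a number. No other measurement bears on this result. The compounds shown leave open whether the charged group at the chain end affects this read-out.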